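The source may report more compounds than this note shows. Statements on the series, on what has been measured and on what is new or still open speak of the compounds shown alone.

Going by the values given here, in a functional assay on MCF7 cells (Homo sapiens) for antiproliferative activity, with a stated time of 96 h (a higher number here means a weaker inhibitor, a lower number a stronger inhibitor), compound 1 `Cc1cc(=O)oc2cc(OCC(=O)c3ccc(C(C)(C)C)cc3)ccc12` gives 20700 nM, the lowest actual number so far. Compound 2 `Cc1cc(=O)oc2cc(OCC(=O)c3ccccc3C(F)(F)F)ccc12` gives 43200 nM, a higher number by a gap beyond the usual scatter. Compound 3 `Cc1cc(=O)oc2cc(OCC(=O)c3ccc4ccccc4c3)ccc12` reads > 100000 nM, which is a limit of the assay and not a number. Compound 4 `Cc1cc(=O)oc2cc(OCC(=O)c3ccc(OC(F)(F)F)cc3)ccc12` keeps the core of compound 1 and swaps one group: trifluoromethoxy in place of tert-butyl on an aromatic carbon, para to a large group (trifluoromethoxy in place of tert-butyl on an aromatic carbon). Among the compounds with values here, no measured pair shows this change, so the expectation is loose. With compound 1 at 20700 nM as the lowest number yet, a modest move towards a higher number is expected, a 1.4-fold higher number from compound 1 to compound 4 (0.16 log units; within the scatter). For compound 4 the estimate is 30000 nM, with an expected range from 12000 nM to 80000 nM.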

Compound 4, half-maximal inhibitory concentration: > 100000 nM
Compound 4 was reported as a limit; the forecaster's own chance of this, stated with the estimate: 15%; middle value at least 3.3-fold (0.52 log units) from the limit.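

This is the first change shown at this position, on an aromatic carbon para to a large group, and the swap is far from neutral in this assay: trifluoromethoxy in place of tert-butyl gives an at least 4.8-fold higher number from compound 1 to compound 4 (0.68 log units; beyond the scatter). The group at this position therefore clearly affects the read-out, even though no ring or other part of the core of compound 1 changes. The full size of the step stays unknown, since compound 4 reads a limit and not a number: the limit of > 100000 nM in this assay, at which 2 of the 4 values shown sit.

Going by these compounds, what stays open is how an amine, a carboxylic acid or a simple methyl at this same position would compare with tert-butyl. The compounds shown also do not tell whether any group here could give a lower number than compound 1.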